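Alkyne Aryl Variation, Step to Compound 4

The compounds below may be only part of what the source reports. "The series", "measured", "known", "first", "only" and "open" are said of these compounds alone.

Measured compounds:
- compound 1, `COC(=O)c1sc2cc(C#Cc3ccccn3)cnc2c1N`; in a functional assay on NCI-H460 cells (Homo sapiens) for inhibition, read by sulforhodamine B assay, with a stated time of 48 h (a higher number here means a weaker inhibitor of growth, a lower number a stronger inhibitor of growth), compound 1 gives 34900 nM
- compound 2, `COC(=O)c1sc2cc(C#Cc3ccccc3OC)cnc2c1N`; compound 2 is reported only as a limit, > 47300 nM
- compound 3, `COC(=O)c1sc2cc(C#Cc3ccsc3)cnc2c1N`; compound 3 gives 24800 nM

Of the two numbers, compound 3 holds the lower one; its nearest neighbour is compound 1, with a 1.4-fold lower number from compound 1 to compound 3 (0.15 log units; within the scatter). Compound 2 sits at the limit of > 47300 nM in this assay, at which 1 of the 3 values shown sits, so both of its steps are floors only: an at least 1.3-fold higher number from compound 1 to compound 2 (0.13 log units; that floor lies within the scatter) and an at least 1.9-fold lower number from compound 2 to compound 3 (0.28 log units; that floor lies within the scatter). All three steps swap the aryl group on the triple-bonded carbon, and none of them reaches beyond the scatter.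

Compound 4, `COC(=O)c1sc2cc(C#Cc3cccc(OC)c3)cnc2c1N`, differs from compound 3 by 3-methoxyphenyl in place of thiophen-3-yl on a triple-bonded carbon. For the measured compounds named here, the steps that bear on this are a 1.4-fold lower number from compound 1 to compound 3 (0.15 log units; within the scatter) and an at least 1.9-fold lower number from compound 2 to compound 3 (0.28 log units; that floor lies within the scatter), both small. The 2-methoxyphenyl analogue reached only a limit, so a methoxyphenyl ring on this position brings a real chance that compound 4 is again reported as a limit rather than a number. Taken together the expectation is no step beyond the scatter, leaning slightly upward: the estimated step is a 1.4-fold higher number from compound 3 to compound 4 (0.15 log units; within the scatter). Compound 4 is therefore expected near 35000 nM, with a range from 14000 nM to 90000 nM.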

Compound 4, concentration for 50% growth inhibition: 49000 nM
Compound 4: middle estimate off by 1.4-fold (0.15 log units), on the low side, within the range that was stated.
By their numbers in this assay, from the lowest: compounds 3, 1 and 4 (each within the scatter of the next).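

In this assay compound 4 returns a number where compound 2 is reported only as a limit, so a methoxyphenyl ring on this triple-bonded carbon does not always end at the limit. Replacing the five-membered aromatic ring of thiophen-3-yl with the six-membered carbon ring of 3-methoxyphenyl gives a 2.0-fold higher number from compound 3 to compound 4 (0.30 log units; within the scatter), and replacing pyridin-2-yl with 3-methoxyphenyl gives a 1.4-fold higher number from compound 1 to compound 4 (0.15 log units; within the scatter), so these three groups are not told apart at this position, despite the change in ring size and in hetero atom. The step from compound 2 to compound 4 cannot be read because compound 2 is reported only as a limit: the limit of > 47300 nM in this assay, at which 1 of the 4 values shown sits.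

From the compounds shown here alone, whether 2-methoxyphenyl and 3-methoxyphenyl differ at all on this carbon therefore stays open. Also open, going by these compounds, is whether any group here gives a step beyond the scatter, for example a phenyl ring carrying a carboxylic acid or an amine, or a longer alkyl chain in place of the aromatic ring.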